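The source may report more compounds than this note shows. Statements on the series, on what has been measured and on what is new or still open speak of the compounds shown alone.

Working notes on the series. All three measured compounds share one core, varied at the aryl on the aromatic nitrogen and at the amine on the ether chain. Compound 1 `COc1cc2c(Oc3ccc(NC(=O)c4nn(-c5ccccc5Br)c(=O)c5ccccc45)cc3F)ccnc2cc1OCCCN1CCCC1` gives 1020 nM in a functional assay on MDA-MB-231 cells (Homo sapiens) for cytotoxicity, read by MTT assay, with a stated time of 72 h; a lower number here means a stronger inhibitor, a higher number a weaker inhibitor. Compound 2 `COc1ccc(-n2nc(C(=O)Nc3ccc(Oc4ccnc5cc(OCCCN6CCCC6)c(OC)cc45)c(F)c3)c3ccccc3c2=O)cc1` gives 3450 nM in this assay, a single-change neighbour of compound 1: a 3.4-fold higher number from compound 1 to compound 2 (0.53 log units; beyond the scatter). Compound 3 `COc1cc2c(Oc3ccc(NC(=O)c4nn(-c5ccc(F)cc5)c(=O)c5ccccc45)cc3F)ccnc2cc1OCCCN1CCN(C)CC1` gives 460 nM in this assay, the lowest of the three numbers, beyond the scatter from compound 1 and further still from compound 2.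

Compound 4 `COc1cc2c(Oc3ccc(NC(=O)c4nn(-c5ccc([N+](=O)[O-])cc5)c(=O)c5ccccc45)cc3F)ccnc2cc1OCCCN1CCN(C)CC1` awaits measurement in this assay. Against compound 3 the difference is nitro in place of fluoro on an aromatic carbon. For the measured compounds named here, no measured step tests this exact exchange; the only one-place step on the same aryl, that from compound 1 to compound 2, replaces the whole ring substituent and was modest, and compounds 1 and 2 carry a different amine from compound 3. The guidance is therefore weak, and a small step, not clearly beyond the scatter, is expected. The expected step is a 1.4-fold higher number from compound 3 to compound 4 (0.15 log units; within the scatter). The estimate for compound 4 in this assay is 650 nM, with a range from 250 nM to 1700 nM.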

Compound 4, half-maximal inhibitory concentration: 3490 nM
For compound 4 the middle estimate is 5.4-fold (0.73 log units) below the measured one; the whole stated range lies below it.
By their numbers in this assay, from the lowest: compound 3; then compound 1; then compounds 2 and 4 (each within the scatter of the next).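

In this assay, the 4-fluorophenyl to 4-nitrophenyl exchange gives a 7.6-fold higher number from compound 3 to compound 4 (0.88 log units; beyond the scatter), with the amine on the ether chain held fixed. This shows that a single exchange on an aromatic carbon para to a large group can move the number beyond the scatter, which the earlier step, a 3.4-fold higher number from compound 1 to compound 2 (0.53 log units; beyond the scatter), could not show, as it exchanged 2-bromophenyl for 4-methoxyphenyl in a different amine setting. No measurement at hand explains the step.

Going by these compounds, it remains open whether other groups at this place, such as nitrile, trifluoromethyl or an amino group, would stay close to fluoro or fall closer to nitro. On these data alone, it is also open whether the exchange of fluoro for nitro gives a similar step with the amine of compound 1 on the ether chain.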